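This account rests on a few compounds, and the source may have more. Where it says the series, first, only, none or still open, it means among the compounds named here.

Working notes on a series built on one shared core. In a functional assay on HepG2 cells (Homo sapiens) for cytotoxicity, read by MTT assay, with a stated time of 48 h (on this read-out higher numbers stand for weaker inhibition and lower numbers for stronger inhibition), compound 1 `COc1cc(-c2nnc3n2NC(c2ccco2)C(C(=O)c2cccs2)S3)cc(OC)c1OC` gives 64100 nM. Compound 2 `COc1cc(-c2nnc3n2NC(c2ccco2)C(C(=O)c2ccc(C)cc2)S3)cc(OC)c1OC` gives 17400 nM in this assay, the change being a 3.7-fold lower number from compound 1 to compound 2 (0.57 log units; beyond the scatter). Compound 3 `COc1cc(-c2nnc3n2NC(c2ccco2)C(C(=O)c2ccc(O)cc2)S3)cc(OC)c1OC` reaches only the limit (the limit of > 100000 nM in this assay, at which 1 of the 3 values shown sits), reported as > 100000 nM in this assay, so its place among the numbers is a floor rather than a value. That floor is framed by an at least 5.7-fold higher number from compound 2 to compound 3 (0.75 log units; beyond the scatter) and by an at least 1.5-fold higher number from compound 1 to compound 3 (0.19 log units; that floor lies within the scatter). Compound 4 `COc1cc(-c2nnc3n2NC(c2ccco2)C(C(=O)c2ccc(C(F)(F)F)cc2)S3)cc(OC)c1OC` differs from compound 3 by trifluoromethyl in place of hydroxy on an aromatic carbon. The step from compound 2 to compound 3 is the one that bears on this change, since it removes the hydroxy that step introduced. Compound 4 is therefore expected to show an at least 4.0-fold lower number from compound 3 to compound 4 (0.60 log units; beyond the scatter), an estimate of 25000 nM in this assay with a range from 8000 nM to 100000 nM.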

Compound 4, half-maximal inhibitory concentration: > 100000 nM
Compound 4: only a limit was reported; the forecaster's own chance of this, stated with the estimate: 25%; middle value at least 4.0-fold (0.60 log units) away from the limit.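

In this assay compound 4 gives a limit and not a number, as compound 3 does: the limit of > 100000 nM in this assay, at which 2 of the 4 values shown sit.

Trifluoromethyl in place of methyl gives an at least 5.7-fold higher number from compound 2 to compound 4 (0.75 log units; beyond the scatter), so hydroxy is no longer the only group on this aromatic carbon to lose a measured value, while methyl in compound 2 keeps one. Against the thiophen-2-yl of compound 1, the 4-(trifluoromethyl)phenyl on the carbonyl carbon gives an at least 1.5-fold higher number from compound 1 to compound 4 (0.19 log units; that floor lies within the scatter).

The step between hydroxy and trifluoromethyl cannot be read, as both ends are limits. Open, from the compounds shown here alone, is whether an amine, a methoxy or an ethyl on this carbon would give a measured value, as methyl does.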